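The Same Chloro Step Repeated on a Second Core

The source may report more compounds than this note shows. Statements on the series, on what has been measured and on what is new or still open speak of the compounds shown alone.

In a physicochemical assay for lipophilicity (a lower number here means a more polar compound, a higher number a more lipophilic compound), compound 1 `CCC(=O)Oc1c(OC)c(OC)c(OC(=O)CC)c2ccccc12` gives 3.44. Compound 3 `CCC(=O)Oc1c(OC)c(OC)c(OC(=O)CC)c2cc(Cl)ccc12` carries chloro in place of hydrogen on an aromatic carbon, and in this assay compound 3 gives 4.3, so that a number 0.86 log units higher from compound 1 to compound 3 (beyond the scatter). Compound 2 `COc1c(OC)c(OC(=O)C(C)C)c2ccccc2c1OC(=O)C(C)C` is built on a different core; the difference between the two cores is not broken down here. In this assay compound 2 gives 4.61, the highest of the three measured numbers. Compound 4 `COc1c(OC)c(OC(=O)C(C)C)c2cc(Cl)ccc2c1OC(=O)C(C)C` carries chloro in place of hydrogen on an aromatic carbon on the core of compound 2; the place is described in the same words as for compound 3, so this is the same change. Because a number 0.86 log units higher from compound 1 to compound 3 (beyond the scatter), a step of similar size is expected from compound 2 to compound 4, namely a number 0.84 log units higher from compound 2 to compound 4 (beyond the scatter). Compound 4 is estimated at 5.45, most likely between 5.05 and 5.85.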

Compound 4, partition coefficient: 5.4
The estimate for compound 4 lay 0.05 log units above the measured number; measured number inside the range.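

In this assay chloro in place of hydrogen on an aromatic carbon gave a step of similar size on both cores, with a number 0.79 log units higher from compound 2 to compound 4 (beyond the scatter) set against a number 0.86 log units higher from compound 1 to compound 3 (beyond the scatter) on the other core. This is a single pair of steps, so it supports carrying the change between these two cores only and shows nothing about other cores or other places on the ring. No measurement shown here explains why the two steps are alike.

The compounds shown leave open whether bromo, an amine or a carboxylic acid in the same place would also give a step of similar size on both cores. They also leave open whether the step would hold with a longer chain on the esters.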